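Swapping One Amide Group on Compound 3

This account rests on a few compounds, and the source may have more. Where it says the series, first, only, none or still open, it means among the compounds named here.

Of the compounds shown here, three have so far been tested in a functional assay on HeLa cells (Homo sapiens) for inhibition, read by MTT assay, with a stated time of 72 h; a lower number here means a stronger inhibitor, a higher number a weaker inhibitor. Compound 1 (`COc1cc(NC(=O)/C=C/c2cccc(OCc3ccccc3)c2)cc(OC)c1OC`) gives 2200 nM, compound 2 (`C=C(Br)C(=O)Nc1cccc(/C=C/C(=O)Nc2cccc3ccccc23)c1`) gives 1400 nM, and compound 3 (`C=C(Br)C(=O)Nc1cccc(/C=C/C(=O)Nc2cccc(F)c2)c1`) gives 1200 nM. Compound 3 lies within the usual scatter of both of the others, so these three results cannot be ranked with any confidence.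

The next compound, compound 4 (`C=C(Br)C(=O)Nc1cccc(/C=C/C(=O)NCc2ccc(C)cc2)c1`), differs from compound 3 in one place: it has 4-methylbenzyl in place of 3-fluorophenyl on an amide-type nitrogen. Among the measured compounds shown here, no measured pair shows the effect of a single change like this one, so the forecast is uncertain. Different groups on that nitrogen still leave compound 2 at 1400 nM and compound 3 at 1200 nM, which suggests that the change will be small. The expected step of a 2.1-fold higher number from compound 3 to compound 4 (0.32 log units; beyond the scatter) in this assay is modest, and its direction toward a weaker inhibitor is only a tentative expectation. Compound 4 is estimated at 2500 nM, with an expected range of 900 nM to 7000 nM.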

Compound 4, half-maximal inhibitory concentration: 1700 nM
Compound 4: the middle estimate sits 1.5-fold (0.17 log units) above what was measured; the range from low to high includes it.
By their numbers in this assay, from the lowest: compounds 3, 2, 4 and 1 (each within the scatter of the next).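

In this assay, among the compounds shown here, putting 4-methylbenzyl in place of 3-fluorophenyl on the amide-type nitrogen gives a 1.4-fold higher number from compound 3 to compound 4 (0.15 log units; within the scatter), the first comparison here in which only this one place differs. Compound 3 and compound 4 therefore cannot be told apart, which shows that this position can carry either of these two groups, each built on one six-membered aromatic ring of carbon only, without a step beyond the scatter. No measurement shown offers an explanation for this result.

A plain benzyl group in this place would help separate the contribution of the methyl from that of the fluorine and the extra carbon. As far as these compounds go, whether the same holds for groups of a different kind, such as one carrying an amine or a carboxylic acid, remains open.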